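From compound 3 to compound 4: adding an isobutyl

The source may hold more compounds than are shown below. What is called first, only, known or untested is meant among the compounds shown, and "the series" means these compounds.

Measured in a functional assay on HeLa cells (Homo sapiens) for antiproliferative activity, read by MTT assay, with a stated time of 48 h; a higher number here means a weaker inhibitor, a lower number a stronger inhibitor:
Compound 1 `COC(=O)CNC(=O)c1ccc(Oc2nc3ccccc3nc2NC(C)(C)C)cc1`: > 50000 nM (a limit)
Compound 2 `COC(=O)[C@H](CC(C)C)NC(=O)c1ccc(Oc2nc3ccccc3nc2NC(C)(C)C)cc1`: > 50000 nM (a limit)
Compound 3 `CC(C)(C)Nc1nc2ccccc2nc1Oc1ccc(C(=O)NCC(=O)O)cc1`: > 50000 nM (a limit)

Compound 3 has no exact number and stands at the limit of > 50000 nM in this assay, at which 3 of the 3 values shown sit. Compound 4 `CC(C)C[C@H](NC(=O)c1ccc(Oc2nc3ccccc3nc2NC(C)(C)C)cc1)C(=O)O` differs from it by one change: isobutyl in place of hydrogen on a saturated chain carbon bound to an amide-type nitrogen and a carbonyl carbon. The closest guide is the same addition made on the methyl ester, a step that the two limits leave unreadable from compound 1 to compound 2. The two other measured changes are a step that the two limits leave unreadable from compound 1 to compound 3 and a step that the two limits leave unreadable from compound 2 to compound 3. None of these gives a size or a direction to build on. The expected step is therefore a number no higher from compound 3 to compound 4 (the limit leaves the size open), with nothing beyond the scatter foreseen. Compound 4 is estimated at 50000 nM, with an expected range of 25000 nM to 100000 nM. Another limit is the most likely report.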

Compound 4, half-maximal inhibitory concentration: 39200 nM
Compound 4: the middle estimate sits 1.3-fold (0.11 log units) above what was measured; low and high end bracket the measured number.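

In this assay, going by these compounds alone, compound 4 is the only compound here with an exact number, so the isobutyl on the saturated chain carbon can now be read, though only as a floor. Adding it gives an at least 1.2-fold lower number from compound 3 to compound 4 (0.10 log units; that floor lies within the scatter), removing the methyl from the ester gives an at least 1.2-fold lower number from compound 2 to compound 4 (0.10 log units; that floor lies within the scatter), and the change in the whole side chain gives an at least 1.2-fold lower number from compound 1 to compound 4 (0.10 log units; that floor lies within the scatter). The steps among compound 1, compound 2 and compound 3 cannot be read, since all three stop at a limit: the limit of > 50000 nM in this assay, at which 3 of the 4 values shown sit.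

Still open, on these data alone, is the true size of these steps. Also open, as far as these compounds go, is whether a longer chain or an amine on this carbon would move the number beyond the scatter.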